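Heteroaryl amides in the shared core: pyridazinyl to thiadiazolyl

The compounds below may be only part of what the source reports. "The series", "measured", "known", "first", "only" and "open" are said of these compounds alone.

Compound 1 `CC(C)[C@H](C(=O)Nc1ccccc1)c1ccc(Cl)cc1` and compound 2 `CC(C)[C@H](C(=O)Nc1cccnn1)c1ccc(Cl)cc1` share a core that differs only on the amide-type nitrogen. In a functional assay on CHO cells for agonist activity at Free fatty acid receptor 2 (Homo sapiens), read by cAMP accumulation (on this read-out higher numbers stand for larger maximal responses and lower numbers for smaller maximal responses), compound 1 gives < 30%, which is a limit of the assay, not a number. In this assay, going by the values given here, compound 2 gives 101%, the only number in the set. The other value, that of compound 1, is a limit (the limit of < 30% in this assay, at which 1 of the 2 values shown sits). Among the compounds with values here, the step of a number at least 71 percentage points higher from compound 1 to compound 2 (beyond the scatter) is the one measured change. Compound 3 `CC(C)[C@H](C(=O)Nc1nncs1)c1ccc(Cl)cc1` carries the change (1,3,4-thiadiazol-2-yl in place of pyridazin-3-yl on an amide-type nitrogen). Both pieces are heteroaryl rings on an amide-type nitrogen, so the step of a number 16 percentage points lower from compound 2 to compound 3 (beyond the scatter) is expected to stay within the scatter or fall modestly. For compound 3 the estimate is 85%, with a range from 50% to 110%.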

Compound 3, largest response reached (reported as efficacy), in percent of the reference or control that the assay uses: 115%
Compound 3: middle estimate off by 30 percentage points, on the low side, and the stated range ends below it.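

In this assay, the place on the amide-type nitrogen accepts a five-membered aromatic ring as well as a six-membered one: 1,3,4-thiadiazol-2-yl in place of pyridazin-3-yl gives a number 14 percentage points higher from compound 2 to compound 3 (beyond the scatter). In place of phenyl, the same ring gives a number at least 85 percentage points higher from compound 1 to compound 3 (beyond the scatter). The value of compound 1 remains a limit, not a number: the limit of < 30% in this assay, at which 1 of the 3 values shown sits.

Open, on these data alone, is whether a pyridin-2-yl or 1,3-thiazol-2-yl group at this place keeps the response, and whether a methyl group on the 1,3,4-thiadiazol-2-yl ring does. As far as these compounds go, how these maximal responses relate to potency also remains open.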